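Swapping an Ester for an Ethyl Amide

The compounds below may be only part of what the source reports. "The series", "measured", "known", "first", "only" and "open" are said of these compounds alone.

Compound 1 `c1ccc(Oc2ccc(-c3nc4cccnc4n3C3CCCC3)cc2)cc1`: in a functional assay on MDA-MB-231 cells (Homo sapiens) for cytotoxicity, read by MTT assay, with a stated time of 24 h (a lower number here means a stronger inhibitor, a higher number a weaker inhibitor), only a limit, not a number, > 10000 nM.
Compound 2 `COC(=O)c1ccc(-c2nc3cccnc3n2C2CCCC2)cc1`: in this assay 350 nM.

Within the data shown here, compound 2 holds the only true number in this set; the other value is a limit of this assay, as noted in the limit of > 10000 nM in this assay, at which 1 of the 2 values shown sits. Among the measured compounds shown here, the single measured step, an at least 28-fold lower number from compound 1 to compound 2 (1.45 log units; beyond the scatter), exchanged the phenoxy group for the methoxycarbonyl group on the aromatic carbon and so moved from a limit to a measurable number.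

Compound 3 `CCNC(=O)c1ccc(-c2nc3cccnc3n2C2CCCC2)cc1` keeps the shared core and the carbonyl of compound 2 but changes the group attached to that carbonyl: ethylamino in place of methoxy on a carbonyl carbon. For the measured compounds named here, no measured step touches this part of the molecule; the one known step concerns a different position and a different kind of exchange, so it offers little guidance on whether the ethylamino group will help or hurt. On that basis the expected change in this assay from compound 2 to compound 3 is small, plausibly within the scatter, in either direction, and estimated as a 1.4-fold higher number from compound 2 to compound 3 (0.15 log units; within the scatter). Compound 3 is therefore expected to give about 500 nM, with a likely range from 150 nM to 2000 nM.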

Compound 3, half-maximal inhibitory concentration: 320 nM
Compound 3: the middle estimate sits 1.6-fold (0.19 log units) above what was measured; the range from low to high includes it.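

In this assay, turning the ester into an ethyl amide leaves the reading where it was: a 1.1-fold lower number from compound 2 to compound 3 (0.04 log units; within the scatter). The group on this carbonyl carbon can therefore change from methoxy to ethylamino, which brings a hydrogen-bond donor that methoxy lacks, with no change beyond the scatter in this cell test, at least for this one pair of groups. The large drop in the number seen earlier with methoxycarbonyl in place of phenoxy also appears with the amide, an at least 31-fold lower number from compound 1 to compound 3 (1.49 log units; beyond the scatter), so it does not depend on having the ester, although the starting value of this step is a limit of the assay and not a number: the limit of > 10000 nM in this assay, at which 1 of the 3 values shown sits.

The compounds shown do not tell how a carboxylic acid, an unsubstituted amide or a chain longer than ethyl on the amide nitrogen would behave on this carbonyl carbon. They also leave open whether the carbonyl is needed at all, a question that a simple amine on the same aromatic carbon could help to answer.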